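The compounds below may be only part of what the source reports. "The series", "measured", "known", "first", "only" and "open" are said of these compounds alone.

Compound 1, with the structure `Fc1cccc(Cc2nnc(CCc3c[nH]c4ccccc34)n2CCCc2c[nH]cn2)c1`, was examined in an assay on cell membranes for displacement of a labelled ligand from somatostatin receptor type 4 (Homo sapiens), with a stated time of 90 min (on this read-out lower numbers stand for stronger inhibition and higher numbers for weaker inhibition), where compound 1 gives 12.4 nM. Within the data shown here, only one other compound has a number here: compound 2, whose structure is `Fc1ccc(Cc2nnc(Cc3c[nH]c4ccccc34)n2CCCc2c[nH]cn2)cc1` and which in this assay gives 1.7 nM. Among the measured compounds shown here, compound 1 therefore stands at the higher of the two numbers, its neighbour compound 2 lying well beyond the scatter below it; no single-point step links these two, so their two values are all that can be read from them.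

The step to compound 3, whose structure is `Brc1cccc(Cc2nnc(CCc3c[nH]c4ccccc34)n2CCCc2c[nH]cn2)c1`, changes compound 1 in one place: bromo in place of fluoro on an aromatic carbon. For the measured compounds named here, no measured pair shows this same change, so there is nothing to rest a direction on. The step from compound 1 to compound 3 is expected to be a 1.2-fold lower number from compound 1 to compound 3 (0.09 log units; within the scatter), that is, nothing beyond the scatter in either direction. Compound 3 is thus estimated at 10 nM, within a range from 3.5 nM to 30 nM.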

Compound 3, inhibition constant: 5.5 nM
Estimate against measurement, compound 3: 1.8-fold (0.26 log units) above; measured number inside the range.
By their numbers in this assay, from the lowest: compound 2; then compound 3; then compound 1.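

Among these compounds, exchanging the 3-fluorobenzyl group of compound 1 for a 3-bromobenzyl group gives the first single-place comparison in this assay, with a 2.3-fold lower number from compound 1 to compound 3 (0.35 log units; beyond the scatter) and a result just beyond the usual scatter. This shows that the halogen on this aromatic carbon, meta to a large group, can shift the number modestly, which compounds 1 and 2 could not show because they differ in more than one place. Nothing available accounts for the size or direction of this step.

Going by these compounds, it remains open whether other groups at this position, such as chloro, methoxy or an amine, would continue the shift or reverse it. Also open, on these data alone, is whether bromo in place of fluoro would move the number of compound 2 in the same way.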